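Swapping the anilide ring for pyridin-3-yl in a clearance series

The compounds below may be only part of what the source reports. "The series", "measured", "known", "first", "only" and "open" are said of these compounds alone.

Measured in an in vitro ADME assay on microsomes from liver (Homo sapiens) for pharmacokinetics, read by LC-MS, with a stated time of 10 min, tested at 1 uM; on this read-out lower numbers stand for slow clearance and higher numbers for fast clearance:
- compound 1 `CN1C[C@H](C(=O)Nc2ccc(C#N)cc2)[C@@H](c2ccc(/C=C/C(=O)Nc3ccccc3N)cc2)C1`: 1 mL/min/kg
- compound 2 `CN1C[C@H](C(=O)Nc2ccc(F)c(Br)c2)[C@@H](c2ccc(/C=C/C(=O)Nc3ccccc3N)cc2)C1`: 15 mL/min/kg
- compound 3 `Cc1cc(NC(=O)[C@H]2CN(C)C[C@@H]2c2ccc(/C=C/C(=O)Nc3ccccc3N)cc2)ccc1Cl`: 15 mL/min/kg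

The three compounds share one core and differ only in the aryl group on the amide-type nitrogen. Compound 3 gives 15 mL/min/kg and stands level with compound 2, together the highest of the three numbers, while compound 1 gives 1 mL/min/kg.

The next compound is compound 4 `CN1C[C@H](C(=O)Nc2cccnc2)[C@@H](c2ccc(/C=C/C(=O)Nc3ccccc3N)cc2)C1`, which keeps the core and changes that same group: pyridin-3-yl in place of 4-chloro-3-methylphenyl on an amide-type nitrogen. Among the measured compounds shown here, three measured steps bear on this place. Going to compound 3 from the 4-cyanophenyl group is a 15-fold higher number from compound 1 to compound 3 (1.18 log units; beyond the scatter), and going to the 3-bromo-4-fluorophenyl group gives a 15-fold higher number from compound 1 to compound 2 (1.18 log units; beyond the scatter). Exchanging the two substituted rings gives no change at the digits printed from compound 2 to compound 3 (within the scatter). Neither halogen-bearing ring therefore separates from the other, and only the halogen-free ring of compound 1 sits low. For the measured compounds named here, the pyridin-3-yl group also carries no halogen, but no measurement yet covers a ring with a hetero atom here, so the parallel with compound 1 is only partial. A sizeable drop is expected, probably not the full distance down to compound 1, and the expected change is a 3.8-fold lower number from compound 3 to compound 4 (0.57 log units; beyond the scatter). For compound 4 the estimated clearance is 4 mL/min/kg, with an expected range from 1 mL/min/kg to 12 mL/min/kg.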

Compound 4, clearance: 10 mL/min/kg
Compound 4: the middle estimate sits 2.5-fold (0.40 log units) below what was measured; low and high end bracket the measured number.
By their numbers in this assay, from the lowest: compound 1; then compounds 4, 2 and 3 (each within the scatter of the next).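

In this assay the pyridin-3-yl group gives a 1.5-fold lower number from compound 3 to compound 4 (0.18 log units; within the scatter) and a 1.5-fold lower number from compound 2 to compound 4 (0.18 log units; within the scatter) and so, within the scatter, compound 4 stays with the two halogen-bearing compounds although its ring carries no halogen and has a hetero atom. Against the 4-cyanophenyl group it gives a 10-fold higher number from compound 1 to compound 4 (1.00 log units; beyond the scatter) and, with that step beyond the scatter, having no halogen on the ring does not by itself bring the low number of compound 1, which among these four compounds belongs to the 4-cyanophenyl group alone. Nothing available here accounts for the separate standing of compound 1. 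

The compounds shown leave open whether the low number follows the nitrile itself, as a plain phenyl ring, a 4-methoxyphenyl ring or a pyridin-3-yl ring carrying a nitrile could help to tell. They also leave open whether pyridin-2-yl or pyridin-4-yl would stay with compound 4, and whether a carboxylic acid or an amine on the ring would move the number at this amide-type nitrogen.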